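The source may report more compounds than this note shows. Statements on the series, on what has been measured and on what is new or still open speak of the compounds shown alone.

Measured compounds in the series:

Compound 1 `COc1cc(-c2nn(-c3cccc(NC(=O)c4cccc(C(F)(F)F)c4)c3)cc2-c2ccncc2)ccc1Cl`. In a functional assay on SNB-75 cells (Homo sapiens) for inhibition, read by sulforhodamine B assay, with a stated time of 48 h (a higher number here means that more compound is tolerated, a lower number that less compound is tolerated), compound 1 gives only the limit > 50000 nM.
Compound 2 `COc1cc(-c2nn(-c3cccc(NC(=O)Nc4ccc(Cl)c(Cl)c4)c3)cc2-c2ccncc2)ccc1Cl`. In this assay compound 2 gives only the limit > 50000 nM.
Compound 3 `COc1cc(-c2nn(-c3cccc(NC(=O)c4ccc(Cl)c(C(F)(F)F)c4)c3)cc2-c2ccncc2)ccc1Cl`. In this assay compound 3 gives only the limit > 32500 nM.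

Compound 3 stands at a limit, as do the two other compounds shown; no step among the three can be read. The change to compound 4 `COc1cc(-c2nn(-c3cccc(NC(=O)Nc4ccc(Cl)c(C(F)(F)F)c4)c3)cc2-c2ccncc2)ccc1Cl` is (4-chloro-3-(trifluoromethyl)phenyl)amino in place of 4-chloro-3-(trifluoromethyl)phenyl on a carbonyl carbon. The nearest measured steps are a step that the two limits leave unreadable from compound 2 to compound 3 and a step that the two limits leave unreadable from compound 1 to compound 2, both an exchange on the same carbonyl carbon between an aryl and an arylamino group, and both left unreadable because of the limit of > 50000 nM in this assay, at which 2 of the 3 values shown sit, and (the limit of > 32500 nM in this assay, at which 1 of the 3 values shown sits). Nothing in the measured values points to a readable change in this assay; the expected step that the limit leaves unreadable from compound 3 to compound 4 is therefore none beyond the scatter, and compound 4 is expected to sit at a limit as well. The estimate for compound 4 is 50000 nM, within 20000 nM to 100000 nM, most likely reported as a limit.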

Compound 4, concentration lethal to 50% of the cells: > 32500 nM
Compound 4: no number, only a limit; the forecaster's own chance of this, stated with the estimate: 85%; the middle value lies beyond the limit too.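

In this assay, within the data shown here, compound 4 gives only the limit > 32500 nM, so no step linking it to compound 1, compound 2 or compound 3 can be read. The compounds shown leave open whether any of these exchanges changes the lethal concentration at all.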